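Methoxyphenyl in place of difluorophenyl on the amide carbonyl

The source may hold more compounds than are shown below. What is called first, only, known or untested is meant among the compounds shown, and "the series" means these compounds.

Compound 3 `Cc1nc(C)c(/C=C/C(=O)c2ccc(NC(=O)c3ccc(F)cc3F)cc2)nc1C` stands second highest of the three numbers shown in a functional assay on MDA-MB-231 cells (Homo sapiens) for antiproliferative activity, read by CCK-8 assay, with a stated time of 72 h (a higher number here means a weaker inhibitor, a lower number a stronger inhibitor), at 1770 nM, though all three lie within the scatter of one another: compound 2 `Cc1nc(C)c(/C=C/C(=O)c2ccc(NC(=O)c3ccc(F)cc3)cc2)nc1C` gives 1670 nM and compound 1 `COc1ccc(C(=O)Nc2ccc(C(=O)/C=C/c3nc(C)c(C)nc3C)cc2)cc1OC` gives 3360 nM. Compound 4 `COc1ccc(C(=O)Nc2ccc(C(=O)/C=C/c3nc(C)c(C)nc3C)cc2)cc1` differs from compound 3 by 4-methoxyphenyl in place of 2,4-difluorophenyl on a carbonyl carbon. For the measured compounds named here, the steps that bear on this exchange are a 1.9-fold lower number from compound 1 to compound 3 (0.28 log units; within the scatter) and a 2.0-fold lower number from compound 1 to compound 2 (0.30 log units; within the scatter), each within the scatter, so swapping the aryl group on this carbonyl has so far not shifted the number beyond the scatter. Compound 4 is therefore expected to show no step beyond the scatter, a 1.4-fold higher number from compound 3 to compound 4 (0.15 log units; within the scatter). The estimate for compound 4 in this assay is 2500 nM, with a range from 1200 nM to 5200 nM.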

Compound 4, half-maximal inhibitory concentration: 1600 nM
Estimate against measurement, compound 4: 1.6-fold (0.19 log units) above; measured number inside the range.
By their numbers in this assay, from the lowest: compounds 4, 2, 3 and 1 (each within the scatter of the next, the first and the last beyond it).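

In this assay, a single methoxy on the aryl group of this carbonyl shows no separation from the fluorinated aryl groups: a 1.1-fold lower number from compound 3 to compound 4 (0.04 log units; within the scatter) and a 1.0-fold lower number from compound 2 to compound 4 (0.02 log units; within the scatter) both stay within the scatter. The series now has its first step beyond the scatter, a modest one, with hydrogen in place of methoxy on an aromatic carbon: a 2.1-fold lower number from compound 1 to compound 4 (0.32 log units; beyond the scatter) in this comparison. No measured evidence accounts for this result. Still open, as far as these compounds go, is whether an amine or a carboxylic acid on this aryl group would give a step beyond the scatter. A saturated ring such as cyclohexyl on the same carbonyl also remains untested in the compounds shown.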